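Fluoropyridine Amide in Place of a Dichlorophenyl

The source may report more compounds than this note shows. Statements on the series, on what has been measured and on what is new or still open speak of the compounds shown alone.

Compound 1, `CNC(=O)c1cc(Oc2ccc3nc(NC(=O)c4ccc(Cl)cc4Cl)sc3c2)ccn1`: 64.4%
Compound 2, `CNC(=O)c1cc(Oc2ccc3nc(NC(=O)c4cc(Cl)cc(Cl)c4)sc3c2)ccn1`: 15.8%

Of the compounds shown here, two have been measured in a functional assay on HCT-116 cells (Homo sapiens) for inhibition, read by MTT assay, with a stated time of 2 days, tested at 100 uM; on this read-out lower numbers stand for less inhibition of growth and higher numbers for more inhibition of growth at the one concentration tested. Compound 1 gives 64.4%, while compound 2 gives 15.8%, the lowest of the two numbers. For the measured compounds named here, the only measured step, a number 48.6 percentage points lower from compound 1 to compound 2 (beyond the scatter), moves the chlorine atoms around the ring on the carbonyl carbon and separates the two compounds by far more than the usual scatter.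

The next compound is compound 3, `CNC(=O)c1cc(Oc2ccc3nc(NC(=O)c4cccc(F)n4)sc3c2)ccn1`. It differs from compound 2 in one place: 6-fluoropyridin-2-yl in place of 3,5-dichlorophenyl on a carbonyl carbon. Going by the values given here, no measured step swaps a carbon-only ring for a ring with a hetero atom at this position, so the one step there, a number 48.6 percentage points lower from compound 1 to compound 2 (beyond the scatter), tells only that a change on this carbonyl carbon can shift the number a long way; it gives no direction for the new ring. The step from compound 2 to compound 3 is therefore estimated with wide bounds, as a number 19.2 percentage points higher from compound 2 to compound 3 (beyond the scatter). Compound 3 is expected to give 35%, in a range from 5% to 75%.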

Compound 3, percent growth inhibition at one concentration: 55.5%
Compound 3: the middle estimate sits 20.5 percentage points below what was measured, within the range that was stated.
By their numbers in this assay, from the lowest: compound 2; then compounds 3 and 1 (each within the scatter of the next).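

In this assay, for the compounds shown here, the step of a number 39.7 percentage points higher from compound 2 to compound 3 (beyond the scatter) shows that this carbonyl carbon can carry a ring with a hetero atom, whereas the earlier compounds carried only dichlorophenyl rings, and that the new ring gives a much higher number than 3,5-dichlorophenyl. The step of a number 8.9 percentage points lower from compound 1 to compound 3 (within the scatter) lies within the scatter, so 6-fluoropyridin-2-yl and 2,4-dichlorophenyl cannot be told apart here, and a carbon-only ring with two chlorine atoms is not needed to reach this level of growth inhibition. Nothing available gives a reason why 3,5-dichlorophenyl stands apart from the other two rings.

With the ring nitrogen and the fluorine entering together, the compounds shown cannot say which of the two goes with the rise, and a plain pyridin-2-yl without fluorine would be the direct test. Also open, on these data alone, is whether a ring is needed at all on this carbonyl carbon, for instance whether a piperidine ring or a short alkyl chain would give a number like those of compound 1 and compound 3.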